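The compounds below may be only part of what the source reports. "The series", "measured", "known", "first", "only" and "open" are said of these compounds alone.

The compounds share one core carrying a chain on one side and a substituted phenyl on the other. Compound 1 `CCCCc1cc2ccccc2nc1-c1cc(-c2ccc(F)cc2)no1` carries a butyl chain and a fluorophenyl; in a functional assay on COLO 205 cells (Homo sapiens) for inhibition, read by MTT assay, with a stated time of 24 h (a lower number here means a stronger inhibitor, a higher number a weaker inhibitor), compound 1 gives 25300 nM. Compound 2 `CCc1cc2ccccc2nc1-c1cc(-c2ccc(C)cc2)no1` carries an ethyl chain and a methylphenyl. In this assay compound 2 gives only a limit, > 100000 nM. Compound 3 `CCc1cc2ccccc2nc1-c1cc(-c2ccc(C(F)(F)F)cc2)no1` carries an ethyl chain and a trifluoromethylphenyl. In this assay compound 3 likewise gives only a limit, > 100000 nM. The a step that the two limits leave unreadable from compound 2 to compound 3 stays unreadable because both values sit at the limit of > 100000 nM in this assay, at which 2 of the 3 values shown sit. So compound 3 stands at that limit, with no number to anchor it.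

Compound 4 `CCCCc1cc2ccccc2nc1-c1cc(-c2ccc(C(F)(F)F)cc2)no1` differs from compound 3 by ethyl in place of hydrogen on a saturated chain carbon, two bonds along the chain from an aromatic carbon. Going by the values given here, no measured step follows this chain change on its own; compound 1 carries the same butyl chain with a different phenyl substituent and gives a number in this assay, while compound 3 gives a limit. The step from compound 3 to compound 4 is therefore expected to be an at least 1.6-fold lower number from compound 3 to compound 4 (0.22 log units; that floor lies within the scatter). Compound 4 is expected to give about 60000 nM in this assay, within 20000 nM to 200000 nM.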

Compound 4, half-maximal inhibitory concentration: 11900 nM
Estimate against measurement, compound 4: 5.0-fold (0.70 log units) above; the measured number lies below the stated range.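

With the trifluoromethyl group held fixed, ethyl to butyl on the chain gives an at least 8.4-fold lower number from compound 3 to compound 4 (0.92 log units; beyond the scatter) in this assay, the first view of a chain change on its own, and it brings the series off the limit to a readable number. That step is a bound and not a size, because compound 3 has only a limit to start from: the limit of > 100000 nM in this assay, at which 2 of the 4 values shown sit. With the butyl chain held fixed, the substituent on the phenyl also counts, since trifluoromethyl in place of fluoro gives a 2.1-fold lower number from compound 1 to compound 4 (0.33 log units; beyond the scatter).

On these data alone, whether the number falls further with a longer chain such as hexyl, or where a propyl chain would fall, stays open. As far as these compounds go, it is also open how a methyl or an amine on the phenyl would read with the butyl chain in place.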